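Swapping Ethyl for Methoxycarbonyl on the Aryl Ring

A few compounds are considered here, and "the series" means these few. Any claim that something is new, unique, unknown or untested is made for them only; others in the source may bear on it.

Of the compounds shown here, three built on a shared core have so far been tested in a functional assay on A549 cells (Homo sapiens) for inhibition; a lower number here means a stronger inhibitor, a higher number a weaker inhibitor. Compound 1 `CC(C)NC1CC(=O)N(c2ccc(F)c(Cl)c2)C1OCC(F)(F)F` reaches only the limit of the assay, > 100000 nM, so no number is known for it. Compound 2 `O=C1C=CC(OCC(F)(F)F)N1c1cc(F)cc(F)c1` gives 5000 nM in this assay. Compound 3 `CCc1ccc(N2C(=O)C=CC2OCC(F)(F)F)cc1` gives 8090 nM, the higher of the two numbers, yet its gap to compound 2 lies within the usual scatter, so the two cannot be ordered.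

Compound 4 `COC(=O)c1ccc(N2C(=O)C=CC2OCC(F)(F)F)cc1` differs from compound 3 in one place: methoxycarbonyl in place of ethyl on an aromatic carbon. Among the measured compounds shown here, no measured pair of compounds shows this particular exchange, so there is nothing to measure its effect against. For the measured compounds named here, compound 2 and compound 3 carry quite different substitution on the aromatic ring yet sit close together, and that is the only guide available. The step from compound 3 to compound 4 is therefore expected to be small, a 1.2-fold higher number from compound 3 to compound 4 (0.09 log units; within the scatter), leaning if anything toward a weaker inhibitor. Compound 4 is estimated at 10000 nM, with a plausible range from 3000 nM to 35000 nM.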

Compound 4, half-maximal inhibitory concentration: 8170 nM
Beside the measured number, compound 4's estimate is 1.2-fold (0.09 log units) above it; low and high end bracket the measured number.
By their numbers in this assay, from the lowest: compounds 2, 3 and 4 (each within the scatter of the next). At a limit, above all of these: compound 1.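

In this assay, methoxycarbonyl in place of ethyl on an aromatic carbon, para to a large group, gives a 1.0-fold higher number from compound 3 to compound 4 (0.00 log units; within the scatter), so the two compounds cannot be told apart. Among the compounds shown here, this is the first direct reading at this position: a group of 4 heavy atoms with 2 hydrogen-bond acceptors replaces one of 2 heavy atoms with 0 hydrogen-bond acceptors, and the read-out shows no detectable difference. Compound 1 alone stands at a limit of the assay, which is not a number: the limit of > 100000 nM in this assay, at which 1 of the 4 values shown sits.

From the compounds shown here alone, whether a carboxylic acid, an amine or a longer chain at this same position would also leave the number within the scatter remains open. This single step also cannot show whether the same exchange would behave alike at other positions on the aromatic ring.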